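Thioether series: phenethyl to 4-methylbenzyl on the sulfur chain

A few compounds are considered here, and "the series" means these few. Any claim that something is new, unique, unknown or untested is made for them only; others in the source may bear on it.

Working notes. The three measured compounds share one core and differ at the sulfur-bearing substituent. Compound 1 `CCc1cc(N2CC[C@@H](C)[C@@H](N(C)c3ncnc4[nH]ccc34)C2)n2ncnc2n1` gives 82200 nM in a functional assay on BGC-823 cells (Homo sapiens) for inhibition, read by MTT assay, with a stated time of 72 h; on this read-out lower numbers stand for stronger inhibition and higher numbers for weaker inhibition. Compound 2 `Cc1cc(N2CC[C@@H](C)[C@@H](N(C)c3ncnc4[nH]ccc34)C2)n2nc(SCC3CC3)nc2n1` gives 36500 nM in this assay, and compound 3 `Cc1cc(N2CC[C@@H](C)[C@@H](N(C)c3ncnc4[nH]ccc34)C2)n2nc(SCCc3ccccc3)nc2n1` gives 28000 nM. Compound 3 has the lowest of the three numbers; compound 2 sits within the scatter of it, while compound 1 stands beyond the scatter above it. Among the measured compounds shown here, the one step on record at the saturated chain carbon bound to a sulfur is a 1.3-fold lower number from compound 2 to compound 3 (0.12 log units; within the scatter), within the scatter.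

Compound 4 `Cc1ccc(CSc2nc3nc(C)cc(N4CC[C@@H](C)[C@@H](N(C)c5ncnc6[nH]ccc56)C4)n3n2)cc1` has not been measured. It differs from compound 3 by 4-methylphenyl in place of benzyl on a saturated chain carbon bound to a sulfur. For the measured compounds named here, no measured pair shows this exact rearrangement; the only comparable step, benzyl in place of cyclopropyl, stayed within the scatter. Compound 4 is therefore expected to change little, no change at the digits printed from compound 3 to compound 4 (within the scatter), with no step beyond the scatter. Compound 4 is estimated at 28000 nM, within 12000 nM to 65000 nM.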

Compound 4, half-maximal inhibitory concentration: 69500 nM
The estimate for compound 4 lay 2.5-fold (0.39 log units) below the measured number; the measured number lies above the stated range.
By their numbers in this assay, from the lowest: compounds 3, 2, 4 and 1 (each within the scatter of the next, the first and the last beyond it).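

At the saturated chain carbon bound to a sulfur, the series now shows a step beyond the scatter: in this assay, 4-methylphenyl in place of benzyl gives a 2.5-fold higher number from compound 3 to compound 4 (0.39 log units; beyond the scatter), whereas benzyl in place of cyclopropyl gave only a 1.3-fold lower number from compound 2 to compound 3 (0.12 log units; within the scatter), within the scatter. Phenethyl to 4-methylbenzyl keeps the same atoms and only joins them differently, so a rearrangement alone is enough to shift the number at this position. Against the cyclopropyl group the same 4-methylphenyl change gives a 1.9-fold higher number from compound 2 to compound 4 (0.28 log units; within the scatter), within the scatter, so that pair cannot be ordered.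

Going by these compounds, whether an amine or a carboxylic acid on the sulfur chain, or a chain longer than phenethyl, would shift the number in either direction remains open. No evidence on hand accounts for the shift from compound 3 to compound 4.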